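The source may hold more compounds than are shown below. What is called first, only, known or untested is meant among the compounds shown, and "the series" means these compounds.

The shared core is that of compound 1 `COc1cc2c(cc1OC)C(CC(=O)O)CC2`, which in a functional assay on the whole organism (strain Wistar) for inhibition, with Rattus norvegicus as the target, read by paw edema, with stated times of 60 min and 3 h, at a dose of 100 mg/kg by the oral route (on this read-out higher numbers stand for more inhibition at the one dose given (going by the name of the read-out) and lower numbers for less inhibition), gives 27.5%. Compound 2 `COc1cc2c(cc1OC)C(CC(N)=O)CC2` gives 30.4%, and compound 3 `COc1cc2c(cc1OC)C(CC(=O)NC1CCCC1)CC2` gives 43.5%. Compound 3 stands highest of the three, with a number 16 percentage points higher from compound 1 to compound 3 (beyond the scatter) and a number 13.1 percentage points higher from compound 2 to compound 3 (beyond the scatter), whereas a number 2.9 percentage points higher from compound 1 to compound 2 (within the scatter) is within the scatter. Compound 4 `COc1cc2c(cc1OC)C(CC(=O)N1CCCCC1)CC2` differs from compound 3 by piperidin-1-yl in place of cyclopentylamino on a carbonyl carbon. Within the data shown here, the measured step that bears on this change is the one with cyclopentyl entering on the amide-type nitrogen, a number 13.1 percentage points higher from compound 2 to compound 3 (beyond the scatter); no measured step takes the hydrogen-bond donor away from that nitrogen, so the direction is uncertain. The expected step is a number 3.5 percentage points lower from compound 3 to compound 4 (within the scatter), not clearly beyond the scatter. Compound 4 is estimated at 40%, within 25% to 55%.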

Compound 4, a percentage reported as inhibition, in the whole organism at one dose (the size of the read-out at that dose, not a potency): 31.9%
For compound 4 the middle estimate is 8.1 percentage points above the measured one, within the range that was stated.
By their numbers in this assay, from the lowest: compounds 1, 2 and 4 (each within the scatter of the next); then compound 3.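

Joining the same atoms differently on the carbonyl carbon is not neutral in this assay: piperidin-1-yl in place of cyclopentylamino gives a number 11.6 percentage points lower from compound 3 to compound 4 (beyond the scatter) and leaves no hydrogen-bond donor in the group. A six-membered ring on this carbon does not by itself separate the amide from amino or hydroxy, with a number 1.5 percentage points higher from compound 2 to compound 4 (within the scatter) and a number 4.4 percentage points higher from compound 1 to compound 4 (within the scatter). No measurement is available to explain this result.

From the compounds shown here alone, whether the rise at compound 3 follows the amide hydrogen or the cyclopentyl ring stays open. A pyrrolidin-1-yl or cyclohexylamino group on the same carbonyl carbon would bear on that question.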